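Aryl replacement on the shared core: compound 4

This account rests on a few compounds, and the source may have more. Where it says the series, first, only, none or still open, it means among the compounds named here.

Three compounds of the series have numbers in a functional assay for inhibition, tested at 40 ug/mL; on this read-out higher numbers stand for a stronger effect at the one concentration tested and lower numbers for a weaker effect. Compound 1 `COc1cccc(-c2cc(-c3cc(C(C)C)c(O)cc3C)[nH]c(=O)c2C#N)c1` gives 30% in this assay. Compound 2 `Cc1cc(O)c(C(C)C)cc1-c1cc(-c2cccs2)c(C#N)c(=O)[nH]1` gives 41%. Compound 3 `COc1cc(-c2cc(-c3cc(C(C)C)c(O)cc3C)[nH]c(=O)c2C#N)ccc1O` gives 32%.

On these numbers compound 3 stands second highest of three. Its nearest neighbour is told by a number 2 percentage points higher from compound 1 to compound 3 (within the scatter), its furthest by a number 9 percentage points lower from compound 2 to compound 3 (within the scatter); neither gap is beyond the scatter, so compound 3 cannot be ordered against either of the other two.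

Compound 4 `Cc1cc(O)c(C(C)C)cc1-c1cc(-c2ccccc2[N+](=O)[O-])c(C#N)c(=O)[nH]1` has no number yet. Its difference from compound 3: 2-nitrophenyl in place of 4-hydroxy-3-methoxyphenyl on an aromatic carbon. This is again an aryl exchange on an aromatic carbon of the shared core, the same kind of change seen in the measured steps. Of those, a number 11 percentage points higher from compound 1 to compound 2 (beyond the scatter) is the only one beyond the scatter, while a number 9 percentage points lower from compound 2 to compound 3 (within the scatter) stays within it; the third, a number 2 percentage points higher from compound 1 to compound 3 (within the scatter), concerns a different change and is also within the scatter. Aryl exchanges at this place have so far shifted the read-out by a modest amount at most, so no step beyond the scatter is expected for compound 4, in either direction.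

Compound 4 is therefore expected to give 34% in this assay, with a range from 20% to 50%. The expected step is a number 2 percentage points higher from compound 3 to compound 4 (within the scatter).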

Compound 4, a percentage reported as inhibition, at one concentration (the size of the read-out at that concentration, not a potency): 25.5%
For compound 4 the middle estimate is 8.5 percentage points above the measured one; measured number inside the range.
By their numbers in this assay, from the lowest: compounds 4, 1, 3 and 2 (each within the scatter of the next, the first and the last beyond it).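

In this assay the exchange of thiophen-2-yl for 2-nitrophenyl gives a number 15.5 percentage points lower from compound 2 to compound 4 (beyond the scatter) and so adds a second six-membered aryl group that stands apart from thiophen-2-yl at this place, opposite the ring nitrogen and ortho to the cyano group. The six-membered aryl groups are not separated from one another, with a number 6.5 percentage points lower from compound 3 to compound 4 (within the scatter) and a number 4.5 percentage points lower from compound 1 to compound 4 (within the scatter) even though 4-hydroxy-3-methoxyphenyl carries a hydrogen-bond donor and 2-nitrophenyl carries none, but compound 3 goes against a clean split from thiophen-2-yl, as a number 9 percentage points lower from compound 2 to compound 3 (within the scatter) shows. Nothing available explains the separation of compound 2 from compound 1 and compound 4.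

Still open, from the compounds shown here alone, is whether an aminophenyl or carboxyphenyl group, a 3-nitrophenyl or 4-nitrophenyl isomer, or a saturated ring such as cyclohexyl would move the read-out beyond the range of these aryl groups. Also open, going by these compounds, is whether thiophen-2-yl keeps its standing against the other groups at further concentrations, since each compound here has a number at one concentration only and none of these numbers is a potency.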